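Trading acetyl for trifluoromethoxy on compound 3

A few compounds are considered here, and "the series" means these few. Any claim that something is new, unique, unknown or untested is made for them only; others in the source may bear on it.

Of the compounds shown here, three with a shared core have been measured in a functional assay on HUVEC cells (Homo sapiens) for inhibition; a higher number here means a weaker inhibitor, a lower number a stronger inhibitor. Compound 1 `CN(c1ccc(NC(=O)Nc2ccccc2)cc1)c1ccnc(Nc2cccc(CS(C)(=O)=O)c2)n1` gives 0.2 nM, compound 2 `CN(c1ccc(NC(=O)Oc2ccccc2)cc1)c1ccnc(Nc2cccc(CS(C)(=O)=O)c2)n1` gives 224 nM, and compound 3 `CC(=O)c1ccc(NC(=O)Nc2ccc(N(C)c3ccnc(Nc4cccc(CS(C)(=O)=O)c4)n3)cc2)cc1` gives 2 nM. Compound 3 therefore holds the middle place, with a number above that of compound 1 and below that of compound 2, both gaps lying beyond the scatter.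

The next compound is compound 4 `CN(c1ccc(NC(=O)Nc2ccc(OC(F)(F)F)cc2)cc1)c1ccnc(Nc2cccc(CS(C)(=O)=O)c2)n1`, which carries trifluoromethoxy in place of acetyl on an aromatic carbon, para to a large group: trifluoromethoxy in place of acetyl on an aromatic carbon.

The closest evidence is a 10-fold higher number from compound 1 to compound 3 (1.00 log units; beyond the scatter), a modest step in which acetyl stands in place of hydrogen on that same carbon. The two large steps, a 1100-fold higher number from compound 1 to compound 2 (3.05 log units; beyond the scatter) and a 110-fold lower number from compound 2 to compound 3 (2.05 log units; beyond the scatter), both involve phenoxy on a carbonyl carbon, a change of a different kind, so they say little here. Within the data shown here, no measured compound carries trifluoromethoxy, which leaves this one modest step as the guide. The number is expected to stay near that of compound 3, leaning slightly lower, with no step beyond the scatter. The expected change is a 1.7-fold lower number from compound 3 to compound 4 (0.22 log units; within the scatter). In this assay the estimate for compound 4 is 1.2 nM, with an expected range from 0.25 nM to 6 nM.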

Compound 4, half-maximal inhibitory concentration: 7 nM
The estimate for compound 4 lay 5.8-fold (0.77 log units) below the measured number; the whole stated range lies below it.
By their numbers in this assay, from the lowest: compound 1; then compound 3; then compound 4; then compound 2.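

Replacing acetyl with trifluoromethoxy on this aromatic carbon, para to a large group, is not a neutral swap in this assay: a 3.5-fold higher number from compound 3 to compound 4 (0.54 log units; beyond the scatter) shows that the position distinguishes between these two groups, not merely between a group and hydrogen. Compared with hydrogen on the same carbon, trifluoromethoxy gives a 35-fold higher number from compound 1 to compound 4 (1.54 log units; beyond the scatter) and is a large step where acetyl was a modest one, so among compound 1, compound 3 and compound 4 both substituted compounds are weaker than the unsubstituted one. The anilino-type link still matters more in this comparison, since a 32-fold lower number from compound 2 to compound 4 (1.51 log units; beyond the scatter) leaves compound 4 far stronger than the phenoxy compound despite the loss at this position.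

The compounds shown leave open whether a smaller group such as fluorine or methoxy, or a quite different one such as an amine or a carboxylic acid, would bring the number back towards that of compound 1 at this carbon. No measurement offered alongside these numbers bears on what separates acetyl, trifluoromethoxy and hydrogen here.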